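Halogen position shift on the ester-bearing aryl ring

A few compounds are considered here, and "the series" means these few. Any claim that something is new, unique, unknown or untested is made for them only; others in the source may bear on it.

Measured so far:
compound 1 `COC(=O)c1cc(Cl)ccc1OC(=O)COc1cc(O)c2c(=O)cc(-c3ccccc3)oc2c1` — 3740 nM
compound 2 `COC(=O)c1c(Cl)cc(Cl)cc1OC(=O)COc1cc(O)c2c(=O)cc(-c3ccccc3)oc2c1` — 43600 nM
compound 3 `COC(=O)c1cc(Br)ccc1OC(=O)COc1cc(O)c2c(=O)cc(-c3ccccc3)oc2c1` — 780 nM

In a functional assay on cells (T-cell, Mus musculus, strain BALB/c) for inhibition, read by MTT assay, with a stated time of 72 h (a lower number here means a stronger inhibitor, a higher number a weaker inhibitor), compound 3 gives the lowest number of the three. Going by the values given here, its nearest neighbour is compound 1, and the one measured step that bears on the present question is a 4.8-fold lower number from compound 1 to compound 3 (0.68 log units; beyond the scatter). Compound 2, carrying two chloro groups on the same ring, gives 43600 nM against 780 nM for compound 3, the widest gap in the set.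

Compound 4 `COC(=O)c1c(Cl)cccc1OC(=O)COc1cc(O)c2c(=O)cc(-c3ccccc3)oc2c1` is the next member. The change from compound 3 is 3-chloro-2-(methoxycarbonyl)phenyl in place of 4-bromo-2-(methoxycarbonyl)phenyl on an oxygen next to a carbonyl group. Among the compounds with values here, the halogen returns to chloro and moves to a different place on the ring, so the step from compound 1 to compound 3 applies in reverse only in part; no measured pair shows a chloro at this new place on its own. Reversing bromo to chloro on the available evidence points to a higher number than compound 3, and compound 2 shows that altering the chloro pattern on this ring can cost much more. The expectation for compound 4 is therefore a modest to sizeable step upward, a 7.7-fold higher number from compound 3 to compound 4 (0.89 log units; beyond the scatter), with wide uncertainty. Compound 4 is estimated at 6000 nM, in the range 1500 nM to 30000 nM.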

Compound 4, half-maximal inhibitory concentration: 38900 nM
Beside the measured number, compound 4's estimate is 6.5-fold (0.81 log units) below it, and the stated range ends below it.
By their numbers in this assay, from the lowest: compound 3; then compound 1; then compounds 4 and 2 (each within the scatter of the next).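

In this assay, going by these compounds alone, the halogen's place on this ring matters on its own: with chloro kept, 3-chloro-2-(methoxycarbonyl)phenyl in place of 4-chloro-2-(methoxycarbonyl)phenyl gives a 10-fold higher number from compound 1 to compound 4 (1.02 log units; beyond the scatter), a large step that no earlier pair could show. The change from 4-bromo-2-(methoxycarbonyl)phenyl combines that shift with the exchange of bromo for chloro and gives a 50-fold higher number from compound 3 to compound 4 (1.70 log units; beyond the scatter), so the two changes cannot be separated within this single step. Hydrogen in place of chloro gives a 1.1-fold lower number from compound 2 to compound 4 (0.05 log units; within the scatter), which lies within the scatter, so the extra chloro makes no readable difference once the 3-chloro-2-(methoxycarbonyl)phenyl pattern is present, and nothing shown here accounts for any of these steps.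

The compounds shown leave open whether bromo would fare any better than chloro in the 3-chloro-2-(methoxycarbonyl)phenyl arrangement, and how the ring would behave with hydrogen alone in place of the halogen. Also open, from the compounds shown here alone, is how a methoxy or an amine would compare with the halogen, and how a carboxylic acid would compare with the methyl ester on this ring.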